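Dropping a chloro group and tolerance in two related cores

A few compounds are considered here, and "the series" means these few. Any claim that something is new, unique, unknown or untested is made for them only; others in the source may bear on it.

Compound 2 `Cc1cc(S(N)(=O)=O)ccc1NC(=O)COc1ccc(F)cc1Oc1ccc2cc(C#N)ccc2c1Cl` and compound 1 `Cc1cc(S(N)(=O)=O)ccc1NC(=O)COc1ccc(F)cc1Oc1ccc2cc(C#N)ccc2c1` differ in one place: hydrogen in place of chloro on an aromatic carbon. In an ADME assay on C8166 cells (Homo sapiens) for cytotoxicity, read by MTT assay (a lower number here means that less compound is tolerated, a higher number that more compound is tolerated), compound 2 gives 39700 nM. For compound 1 the value is a limit of the assay: in this assay compound 1 gives > 395000 nM. The step of an at least 9.9-fold higher number from compound 2 to compound 1 (0.99 log units; beyond the scatter) is given only as a lower bound due to the limit of > 395000 nM in this assay, at which 1 of the 3 values shown sits. Compound 3 `Cc1cc(S(N)(=O)=O)ccc1NC(=O)COc1ccc(Cl)cc1Oc1c(C)cc2ccccc2c1Cl` gives 42600 nM in this assay; the difference between its core and that of compound 2 is not broken down here. Compound 4 `Cc1cc(S(N)(=O)=O)ccc1NC(=O)COc1ccc(Cl)cc1Oc1cc2ccccc2cc1C` carries the same kind of change: hydrogen in place of chloro on an aromatic carbon. Here the place is also meta to a methyl group, which the earlier place is not. From compound 3 to compound 4 a step of about a 7.0-fold higher number from compound 3 to compound 4 (0.85 log units; beyond the scatter) is expected, resting on the step of an at least 9.9-fold higher number from compound 2 to compound 1 (0.99 log units; beyond the scatter). Compound 4 is therefore estimated at 300000 nM, between 100000 nM and 1000000 nM.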

Compound 4, half-maximal cytotoxic concentration: 76700 nM
Compound 4: middle estimate off by 3.9-fold (0.59 log units), on the high side; the measured number lies below the stated range.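

In this assay, the change of chloro to hydrogen gives a 1.8-fold higher number from compound 3 to compound 4 (0.26 log units; within the scatter), so on this core it has no effect that can be told apart from repeat scatter. The change therefore does not carry over in size from one core to the other, although the number rises on both: the same change on two cores in this assay, an at least 9.9-fold higher number (0.99 log units; beyond the scatter) from compound 2 to compound 1 and a 1.8-fold higher number (0.26 log units; within the scatter) from compound 3 to compound 4, at least 5.5-fold (0.74 log units) apart, beyond the scatter of two such steps. From the compounds shown here alone, compound 1 gives > 395000 nM, which is a limit of the assay, so the true size of its step stays unknown, and two cores cannot show how the change would behave on a third.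

Going by these compounds, it remains open which difference between the cores, such as the nitrile or the methyl group, sets the size of the step. Also open, on these data alone, is how a bromo group or an amine at this place would compare.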